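The source may hold more compounds than are shown below. What is called first, only, known or untested is meant among the compounds shown, and "the series" means these compounds.

Of the compounds shown here, two share one core and have been measured in a functional assay on MCF7 cells (Homo sapiens) for inhibition, read by sulforhodamine B assay, with a stated time of 24 h; on this read-out higher numbers stand for weaker inhibition of growth and lower numbers for stronger inhibition of growth. Compound 1, `CCOC(=O)C1=C(C)NC(=O)NC1c1cn(-c2ccccc2)nc1-c1ccc(Cl)cc1`, carries an ethoxy group on its carbonyl carbon; in this assay compound 1 gives 68800 nM. Compound 2, `CC1=C(C(=O)Nc2ccc(C)cc2)C(c2cn(-c3ccccc3)nc2-c2ccc(Cl)cc2)NC(=O)N1`, carries a (4-methylphenyl)amino group there instead; in this assay compound 2 gives 69700 nM. The step of a 1.0-fold higher number from compound 1 to compound 2 (0.01 log units; within the scatter) shows that this exchange left the growth inhibition essentially unchanged, and the two numbers sit within the usual scatter of each other, so neither compound can be called the stronger one.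

Compound 3, `COc1ccc(NC(=O)C2=C(C)NC(=O)NC2c2cn(-c3ccccc3)nc2-c2ccc(Cl)cc2)cc1`, differs from compound 2 by methoxy in place of methyl on an aromatic carbon. Among the measured compounds shown here, no measured step touches this part of the molecule, so the only guide is the single exchange from compound 1 to compound 2, which altered the group on the carbonyl carbon and produced no shift beyond the scatter. On that basis, compound 3 is expected to stay close to compound 2, with an estimated step of a 1.0-fold higher number from compound 2 to compound 3 (0.00 log units; within the scatter). The estimate for compound 3 in this assay is 70000 nM, with a range from 30000 nM to 160000 nM.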

Compound 3, concentration for 50% growth inhibition: 69700 nM
Compound 3: middle estimate off by 1.0-fold (0.00 log units), on the high side; measured number inside the range.
By their numbers in this assay, from the lowest: compounds 1, 2 and 3 (each within the scatter of the next).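

Among the compounds shown here, exchanging methyl for methoxy on the aromatic carbon para to a large group gives no change at the digits printed from compound 2 to compound 3 (within the scatter) in this assay, which is the first reading from the outer ring of the (4-methylphenyl)amino group rather than from the group on the carbonyl carbon as a whole. The direct exchange of ethoxy for (4-methoxyphenyl)amino on that carbonyl carbon gives a 1.0-fold higher number from compound 1 to compound 3 (0.01 log units; within the scatter), so a second aromatic amino group also lies within the scatter of the ethoxy compound, and the earlier reading for (4-methylphenyl)amino is not a lone case among these three compounds. No measurement here offers an explanation for these closely matched numbers.

From the compounds shown here alone, with only methyl and methoxy at this ring position, it remains open whether a very different group there, such as an amine or a carboxylic acid, would give a number beyond the scatter. The 4-chlorophenyl and phenyl groups are the same in all three compounds, so it is also unknown whether exchanging either of them, for example chlorine for a longer chain, would shift growth inhibition.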